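A few compounds are considered here, and "the series" means these few. Any claim that something is new, unique, unknown or untested is made for them only; others in the source may bear on it.

Working notes on the series. Compound 2 `CCOC(=O)c1ccc(CO/N=C/c2c(C)nn(C)c2Oc2ccc(Cl)cc2)cc1` has the highest number of the three measured compounds in a functional assay on HepG2 cells (Homo sapiens) for antiproliferative activity, tested at 1 uM; a higher number here means more inhibition at the concentration tested (going by the name of the read-out), a lower number less inhibition: in that assay compound 2 gives 27.4%. The nearest number belongs to compound 3 `Cc1nn(C)c(Oc2ccccc2)c1/C=N/OCc1ccc(C(F)(F)F)cc1`, which in this assay gives 5.8%, a gap beyond the scatter. Furthest off is compound 1 `Cc1c(CO/N=C/c2c(-c3ccccc3)nn(-c3ccccc3)c2Oc2ccc(Cl)cc2)cccc1-c1ccccc1`, which in this assay gives -14.8%, again beyond the scatter. Note that compound 3 carries a phenoxy group without the chlorine and a trifluoromethyl on the benzyl ring, so no single step connects any two measured compounds.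

Compound 4 `Cc1nn(C)c(Oc2ccc(Cl)cc2)c1/C=N/OCc1ccc([N+](=O)[O-])cc1` keeps the core of compound 2 and changes only the benzyl substituent: nitro in place of ethoxycarbonyl on an aromatic carbon. Among the compounds with values here, no measured pair shows this change. Both acceptors are retained and the group shrinks. The expected outcome is a modest fall, with a step of a number 12.4 percentage points lower from compound 2 to compound 4 (beyond the scatter) from compound 2 to compound 4 that may well sit within the scatter. For compound 4 in this assay the estimate is 15%, ranging from -10% to 38%.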

Compound 4, a percentage reported as inhibition, at one concentration (the size of the read-out at that concentration, not a potency): 18.4%
The estimate for compound 4 lay 3.4 percentage points below the measured number; the range from low to high includes it.
By their numbers in this assay, from the lowest: compound 1; then compound 3; then compounds 4 and 2 (each within the scatter of the next).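

In this assay, within the data shown here, nitro in place of ethoxycarbonyl on an aromatic carbon, para to a large group, gives a number 9 percentage points lower from compound 2 to compound 4 (within the scatter), the first comparison that differs in one place. At this position, ethoxycarbonyl can therefore be exchanged for nitro, a group with fewer heavy atoms and the same count of hydrogen-bond acceptors, without a step beyond the scatter at the single concentration tested. Nothing at hand offers an explanation for this result.

From the compounds shown here alone, it remains open whether a carboxylic acid or an amine on the same aromatic carbon would stay within the scatter of compound 2 and compound 4. Going by these compounds, it is also open whether the nitro for ethoxycarbonyl exchange would give a similar step on a different core, such as that of compound 1.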